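The source may report more compounds than this note shows. Statements on the series, on what has been measured and on what is new or still open speak of the compounds shown alone.

Measured so far:
Compound 1, `O=C(NCc1ccc(S(=O)(=O)c2ccccc2)cc1)c1cc2cnccc2[nH]1`, gives 3000 nM in a physicochemical assay for solubility, in phosphate buffer, with a stated time of 24 h, at pH 7.4, tested at 100 uM; a higher number here means a more soluble compound, a lower number a less soluble compound.
Compound 2, `O=C(NCc1ccc(S(=O)(=O)c2ccccc2)cc1)N1CCc2ccncc2C1`, gives 115000 nM in this assay.
Compound 3, `O=C(NCc1ccc(S(=O)(=O)C2CCCOC2)cc1)N1Cc2ccncc2C1`, gives 208000 nM in this assay.

Among these three numbers compound 3 stands highest. Its nearest neighbour is compound 2, whose value lies within the usual scatter of a repeated measurement, so the two cannot be placed in any order. Its furthest neighbour is compound 1, whose far lower value does lie beyond the scatter, so compound 1 is clearly the least soluble of the three.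

The unmeasured compound 4, `O=C(NCc1ccc(S(=O)(=O)N2CC3(CCOCC3)C2)cc1)N1Cc2ccncc2C1`, differs from compound 3 in one place: a group of 9 heavy atoms (7 carbon, 1 nitrogen, 1 oxygen; one four-membered non-aromatic ring with 1 hetero atom, one six-membered non-aromatic ring with 1 hetero atom) in place of a group of 6 heavy atoms (5 carbon, 1 oxygen; one six-membered non-aromatic ring with 1 hetero atom), on a sulfonyl sulfur. The group entering on the sulfonyl sulfur brings a nitrogen along with its oxygen and adds a four-membered ring, while the count of hydrogen-bond acceptors stays the same. Within the data shown here, no measured pair shows this kind of change, so nothing here tells which way the number should move. The step from compound 3 to compound 4 is expected to be small, a 1.4-fold lower number from compound 3 to compound 4 (0.14 log units; within the scatter), and may well stay within the scatter. Compound 4 is therefore estimated at 150000 nM, with a range from 50000 nM to 350000 nM.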

Compound 4, solubility: 272000 nM
Estimate against measurement, compound 4: 1.8-fold (0.26 log units) below; the measured number falls inside the stated range.
By their numbers in this assay, from the lowest: compound 1; then compounds 2, 3 and 4 (each within the scatter of the next, the first and the last beyond it).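

Among these compounds, the step at the sulfonyl sulfur is the first single-place comparison: in this assay, replacing oxan-3-yl with the larger group carrying a four-membered ring and a nitrogen gives a 1.3-fold higher number from compound 3 to compound 4 (0.12 log units; within the scatter). That step lies within the scatter, so compound 3 and compound 4 cannot be placed in order, and this one exchange produces no measurable difference in the read-out. Nothing shown offers an explanation of this result.

Still open, as far as these compounds go, is how the number would respond at this sulfonyl sulfur to a group of another kind, such as a piperidine, a primary amine or a carboxylic acid. The phenyl group of compound 1 and compound 2 also cannot be weighed against these groups, as each of those compounds differs from compound 3 in more than one place.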